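3-Methylphenyl for Pyridin-4-yl: An Expected Efficacy Step

The compounds below may be only part of what the source reports. "The series", "measured", "known", "first", "only" and "open" are said of these compounds alone.

Measured so far:
compound 1, `CC(Oc1ccccc1-c1ccncc1)C1=NCCN1`: < 0.3
compound 2, `CC(Nc1ccccc1-c1ccccc1)C1=NCCN1`: 0.5

In a functional assay on CHO cells for agonist activity at Alpha-2B adrenergic receptor (Homo sapiens) (on this read-out lower numbers stand for smaller maximal responses and higher numbers for larger maximal responses), compound 1 reports only a limit of the assay, < 0.3, so where it stands on the numbers shown is a bound and not a value (the limit of < 0.3 in this assay, at which 1 of the 2 values shown sits). Going by the values given here, compound 2 gives 0.5 in this assay; no single-point step connects it to compound 1, so the two values show only that compound 2 reaches a measurable response where compound 1 does not.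

Compound 3, `Cc1cccc(-c2ccccc2OC(C)C2=NCCN2)c1`, is compound 1 with 3-methylphenyl in place of pyridin-4-yl on an aromatic carbon. Among the compounds with values here, no measured step covers this change, so its size is open. Compound 3 is expected to move by a number no lower from compound 1 to compound 3 (the limit leaves the size open), a step hardly beyond the usual scatter and, if anything, upward. Compound 3 is therefore estimated at 0.3, within 0.1 to 0.55, with a fair chance that only a limit is reported again.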

Compound 3, intrinsic activity: the largest response reached, as a fraction of the reference agonist's: < 0.3
Compound 3: no number, only a limit; the forecaster's own chance of this, stated with the estimate: 40%; the middle value lies on the limit itself.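

In this assay no step can be read from compound 1 to compound 3, because both compounds report only a limit and not a number: the limit of < 0.3 in this assay, at which 2 of the 3 values shown sit. The compounds shown leave open whether 3-methylphenyl and pyridin-4-yl differ at all in maximal response.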